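Replacing the indanol amine substituent with a methoxyphenylethyl group

This account rests on a few compounds, and the source may have more. Where it says the series, first, only, none or still open, it means among the compounds named here.

Compound 1 `O=S(=O)(NCC1CCN(CCCc2c[nH]c3ccc(-n4cnnc4)cc23)CC1)c1ccccc1` gives 73% in a functional assay on CHO cells for activation of 5-hydroxytryptamine receptor 1D (Homo sapiens), read by GTPgammaS binding; a lower number here means a smaller maximal response, a higher number a larger maximal response. Compound 2 `O[C@@H]1Cc2ccccc2[C@H]1NC1CCN(CCCc2c[nH]c3ccc(-n4cnnc4)cc23)CC1` carries (2-hydroxy-2,3-dihydro-1H-inden-1-yl)amino in place of ((phenylsulfonyl)amino)methyl on a saturated ring carbon, and in this assay compound 2 gives 75%. The step of a number 2 percentage points higher from compound 1 to compound 2 (within the scatter) shows that this exchange left the maximal response essentially unchanged. Among the two numbers known, compound 2 thus sits beside compound 1 with a gap that is within the scatter, so neither can be called the larger responder.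

Compound 3 `COC[C@H](NC1CCN(CCCc2c[nH]c3ccc(-n4cnnc4)cc23)CC1)c1ccccc1` differs from compound 2 by 2-methoxy-1-phenylethyl in place of 2-hydroxy-2,3-dihydro-1H-inden-1-yl on an amine nitrogen, the change sitting on the amine nitrogen whose other neighbour is a saturated ring carbon. Among the compounds with values here, the only measured step that bears on this position is a number 2 percentage points higher from compound 1 to compound 2 (within the scatter), and it was within the scatter even though a much larger group was swapped. On that basis no step beyond the scatter is expected in this assay, so the expected step of a number 3 percentage points lower from compound 2 to compound 3 (within the scatter) is small. Compound 3 is therefore estimated at 72%, with a range from 55% to 90%.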

Compound 3, largest response reached (reported as efficacy), in percent of the reference or control that the assay uses: 93%
Compound 3: the middle estimate sits 21 percentage points below what was measured; the measured number lies above the stated range.
By their numbers in this assay, from the lowest: compounds 1 and 2 (each within the scatter of the next); then compound 3.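

In this assay the step of a number 18 percentage points higher from compound 2 to compound 3 (beyond the scatter) shows that the maximal response is sensitive to the group on this amine nitrogen, which the earlier pair, with its step within the scatter, gave no sign of. The sensitivity appears even though 2-hydroxy-2,3-dihydro-1H-inden-1-yl and 2-methoxy-1-phenylethyl have the same heavy-atom count, while the entering group lacks the five-membered non-aromatic ring and the hydrogen-bond donor and has one defined stereocentre fewer. The step of a number 20 percentage points higher from compound 1 to compound 3 (beyond the scatter) places compound 3 clearly above the sulfonamide as well, making it the highest of the compounds shown in this assay. Nothing available explains the rise.

The compounds shown leave open which of these differences matters, as the ring, the donor and the stereocentre all change together; 2-hydroxy-1-phenylethyl and 2-methoxy-2,3-dihydro-1H-inden-1-yl on the same nitrogen would separate the free hydroxyl from the ring. Going by these compounds, the role of the single stereocentre also remains open, since only one configuration of 2-methoxy-1-phenylethyl appears here, and its mirror-image form would address that.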